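Chloro for methyl: from compound 3 to compound 4

A few compounds are considered here, and "the series" means these few. Any claim that something is new, unique, unknown or untested is made for them only; others in the source may bear on it.

Measured so far in a functional assay on T47D cells (Homo sapiens) for inhibition, read by sulforhodamine B assay, with a stated time of 48 h; a lower number here means a stronger inhibitor of growth, a higher number a weaker inhibitor of growth:
compound 1 `COC(=O)[C@@]1(C)CCC=C2[C@@H]1CC[C@@H](C)[C@]2(C)Cc1c[nH]c2ccc(OC)cc12` gives 3700 nM
compound 2 `COC(=O)[C@@]1(C)CC[C@@H]2C3=C1CC[C@@H](C)[C@]3(C)C[C@@H]1c3ccccc3N[C@H]21` gives 35000 nM
compound 3 `COC(=O)[C@@]1(C)CC[C@@H]2C3=C1CC[C@@H](C)[C@]3(C)C[C@@H]1c3cccc(C)c3N[C@H]21` gives 29000 nM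

Compound 3 holds the second highest of the three numbers. Its nearest neighbour is compound 2, with a 1.2-fold lower number from compound 2 to compound 3 (0.08 log units; within the scatter); compound 1 lies furthest away, with a lower number, and that gap is beyond the scatter.

Compound 4 `COC(=O)[C@@]1(C)CC[C@@H]2C3=C1CC[C@@H](C)[C@]3(C)C[C@@H]1c3cccc(Cl)c3N[C@H]21` is not yet measured. It differs from compound 3 by chloro in place of methyl on an aromatic carbon. Among the compounds with values here, the only measured step that touches this aromatic carbon is the one from hydrogen to methyl, a 1.2-fold lower number from compound 2 to compound 3 (0.08 log units; within the scatter), and it stayed within the scatter. Within the data shown here, no step from methyl to chloro, or to any halogen, exists, so the direction of the present change is open. Because the step of a 1.2-fold lower number from compound 2 to compound 3 (0.08 log units; within the scatter) stayed within the scatter, the expected step for compound 4 is a 1.2-fold lower number from compound 3 to compound 4 (0.06 log units; within the scatter). Compound 4 is estimated at 25000 nM, with a range from 9000 nM to 70000 nM.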

Compound 4, concentration for 50% growth inhibition: 50000 nM
For compound 4 the middle estimate is 2.0-fold (0.30 log units) below the measured one; the measured number falls inside the stated range.
By their numbers in this assay, from the lowest: compound 1; then compounds 3, 2 and 4 (each within the scatter of the next).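

In this assay this aromatic carbon, ortho to a fused ring and meta to a fused ring, has now carried hydrogen, methyl and chloro, and both a 1.7-fold higher number from compound 3 to compound 4 (0.24 log units; within the scatter) and a 1.4-fold higher number from compound 2 to compound 4 (0.15 log units; within the scatter) leave chloro unresolved from the other two groups. A first halogen here therefore gives the same flat reading that methyl gave, so across compounds 2, 3 and 4 this position shows no response that can be read. Nothing available accounts for this flat reading.

Still open, as far as these compounds go, is whether an amine, a hydroxyl or a carboxylic acid on this carbon would give a step beyond the scatter. Also open, from the compounds shown here alone, is whether the other aromatic carbons of this ring would prove as flat as this one.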